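Swapping the aryl group on a shared pyrazole-acid core

This account rests on a few compounds, and the source may have more. Where it says the series, first, only, none or still open, it means among the compounds named here.

Compound 1, `COc1cc(C#N)cc(-c2c(C)nn(-c3nc(-c4ccc(Cl)c(Cl)c4)c(SC(C)C)s3)c2C(=O)O)c1`, gives 5200 nM in a functional assay on BJAB cells (Homo sapiens) for antiproliferative activity, with a stated time of 4 days; a higher number here means that more compound is needed for the effect, a lower number that less compound is needed.
Compound 2, `Cc1nn(-c2nc(-c3ccc(Cl)c(Cl)c3)c(SC(C)C)s2)c(C(=O)O)c1-c1cccc(Cl)c1`, gives 13600 nM in this assay.
Compound 3, `Cc1nn(-c2nc(-c3ccc(Cl)c(Cl)c3)c(SC(C)C)s2)c(C(=O)O)c1-c1ccccc1C(F)(F)F`, gives 5200 nM in this assay.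

All three share one core and differ only in the aryl ring attached to an aromatic carbon of the five-membered ring. Compound 3 sits level with compound 1, the pair making the lowest numbers of the three, while compound 2 stands apart: a 2.6-fold lower number from compound 2 to compound 3 (0.42 log units; beyond the scatter), and a 2.6-fold higher number from compound 1 to compound 2 (0.42 log units; beyond the scatter). The step from compound 1 to compound 3 shows no change within the scatter.

Compound 4, `CC(=O)Nc1ccc(-c2c(C)nn(-c3nc(-c4ccc(Cl)c(Cl)c4)c(SC(C)C)s3)c2C(=O)O)cc1`, carries a further aryl variant at the same place: 4-acetamidophenyl in place of 2-(trifluoromethyl)phenyl on an aromatic carbon. Going by the values given here, the steps that bear on this are the earlier aryl swaps, which moved the number by a modest amount at most or not at all. With no measured aryl carrying a hydrogen-bond donor, the direction is open. A small to modest shift upward is expected, a 1.5-fold higher number from compound 3 to compound 4 (0.19 log units; within the scatter), so compound 4 is estimated at 8000 nM, with a range of 3000 nM to 25000 nM.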

Compound 4, half-maximal effective concentration: 139000 nM
Estimate against measurement, compound 4: 17-fold (1.24 log units) below, outside the stated range (above it).
By their numbers in this assay, from the lowest: compounds 1 and 3 (each within the scatter of the next); then compound 2; then compound 4.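

In this assay this position proved far more sensitive than the earlier aryl swaps had suggested: placing 4-acetamidophenyl on this aromatic carbon gives a 27-fold higher number from compound 3 to compound 4 (1.43 log units; beyond the scatter) and a 10-fold higher number from compound 2 to compound 4 (1.01 log units; beyond the scatter) and also a 27-fold higher number from compound 1 to compound 4 (1.43 log units; beyond the scatter), all large steps, whereas the largest earlier step was only modest, a 2.6-fold higher number from compound 1 to compound 2 (0.42 log units; beyond the scatter). So the aryl group here is not freely interchangeable, even though 2-(trifluoromethyl)phenyl and 4-acetamidophenyl have the same heavy-atom count, which shows that this count alone does not set the number in this series; the entering group differs in bringing a hydrogen-bond donor and acceptor and a double bond outside the ring. No measurement at hand explains why the number rises so steeply at this position.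

The compounds shown leave open whether the rise belongs to the acetamido group itself or to where it sits on the phenyl ring, as both differ from the groups before it. A 3-acetamidophenyl group, or a phenyl ring bearing a simple amine or a carboxylic acid in the 4-position, would be the kind of comparison that could begin to separate these two readings.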